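Amino for methoxy on the long-chain compound

This account rests on a few compounds, and the source may have more. Where it says the series, first, only, none or still open, it means among the compounds named here.

compound 1 `CCCCC(CCO)n1cnc2c(OC)ncnc21`: > 50000 nM
compound 2 `CCCCCCC(CCO)n1cnc2c(N)ncnc21`: > 50000 nM
compound 3 `CCCCCCCC(CCO)n1cnc2c(OC)ncnc21`: 23900 nM

Going by the values given here, in a functional assay on SW480 cells (Homo sapiens) for antiproliferative activity, read by MTT assay, with a stated time of 48 h (a lower number here means a stronger inhibitor, a higher number a weaker inhibitor), compound 3 is the only compound with a number, 23900 nM. Compound 1 gives only a limit, > 50000 nM. Compound 2 also gives only a limit, > 50000 nM. The next compound is compound 4 `CCCCCCCC(CCO)n1cnc2c(N)ncnc21`, with this change from compound 3: amino in place of methoxy on an aromatic carbon. Among the compounds with values here, the one measured step, an at least 2.0-fold lower number from compound 1 to compound 3 (0.32 log units; beyond the scatter), lengthens the chain and bears only indirectly on this exchange. Compound 2 carries amino too, but on a shorter chain. Within the data shown here, no measured step isolates amino against methoxy, so no clear shift is expected in this assay. The expected step, a 1.2-fold higher number from compound 3 to compound 4 (0.07 log units; within the scatter), is estimated to stay within the scatter. For compound 4 the estimate is 28000 nM, with an expected range of 12000 nM to 50000 nM.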

Compound 4, half-maximal inhibitory concentration: > 50000 nM
Compound 4 gave a limit, no number; the forecaster's own chance of this, stated with the estimate: 30%; middle value at least 1.7-fold (0.25 log units) from the limit.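

In this assay, going by these compounds alone, amino in place of methoxy on an aromatic carbon next to the ring nitrogen gives an at least 2.0-fold higher number from compound 3 to compound 4 (0.32 log units; beyond the scatter), the first measured step that isolates this exchange. On this long chain, methoxy is the group that gives a number, while compound 4 with amino gives only a limit. Compound 2 and compound 4 both carry limits, so the step from compound 2 to compound 4 cannot be read.

As far as these compounds go, the full size of the exchange stays open, with the series resting largely on one limit: the limit of > 50000 nM in this assay, at which 3 of the 4 values shown sit. From the compounds shown here alone, whether ethoxy or methylamino at this position, or a longer chain on the methoxy compound, would give a lower number than compound 3 also stays open.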